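A few compounds are considered here, and "the series" means these few. Any claim that something is new, unique, unknown or untested is made for them only; others in the source may bear on it.

Among the measured compounds shown here, compound 3 `Fc1cc(-c2ccccn2)cc(-n2nnc(-c3ccccn3)n2)c1` gives 39 nM in a functional assay for antagonist activity at metabotropic glutamate receptor 5 (Rattus norvegicus); a higher number here means a weaker inhibitor, a lower number a stronger inhibitor; it stands second highest of the three numbers known, with compound 1 `Cc1ccccc1-c1cc(F)cc(-n2nnc(-c3ccccn3)n2)c1` at 120 nM nearest and compound 2 `N#Cc1ccccc1-c1cc(F)cc(-n2nnc(-c3ccccn3)n2)c1` at 6 nM furthest. The steps are a 3.1-fold lower number from compound 1 to compound 3 (0.49 log units; beyond the scatter), a 20-fold lower number from compound 1 to compound 2 (1.30 log units; beyond the scatter) and a 6.5-fold higher number from compound 2 to compound 3 (0.81 log units; beyond the scatter). Compound 4 `Cc1cccnc1-c1cc(F)cc(-n2nnc(-c3ccccn3)n2)c1` differs from compound 3 by methyl in place of hydrogen on an aromatic carbon. For the measured compounds named here, no measured step changes exactly this; the nearest comparison is compound 1 against compound 3, where the ring lacking a nitrogen but carrying a methyl gives the higher number, yet that step mixes two changes. A modest increase in this assay, or none beyond the scatter, is therefore expected, written as a 1.8-fold higher number from compound 3 to compound 4 (0.25 log units; within the scatter). Compound 4 is estimated at 70 nM, within 25 nM to 250 nM.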

Compound 4, half-maximal inhibitory concentration: 31 nM
The estimate for compound 4 lay 2.3-fold (0.35 log units) above the measured number; the range from low to high includes it.
By their numbers in this assay, from the lowest: compound 2; then compounds 4 and 3 (each within the scatter of the next); then compound 1.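

In this assay, methyl on this aromatic carbon, ortho to a large group, leaves the pyridine compounds level, with a 1.3-fold lower number from compound 3 to compound 4 (0.10 log units; within the scatter). With a methyl present on both rings, the ring nitrogen alone separates two compounds, in a 3.9-fold lower number from compound 1 to compound 4 (0.59 log units; beyond the scatter), while a 5.2-fold higher number from compound 2 to compound 4 (0.71 log units; beyond the scatter) shows that 3-methylpyridin-2-yl does not match 2-cyanophenyl. No evidence is available that explains these steps. Going by these compounds, whether methoxy, ethyl or an amine on this same carbon would also leave the number unchanged remains open.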